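Swapping the aryl ring of a weakly active enone

The source may hold more compounds than are shown below. What is called first, only, known or untested is meant among the compounds shown, and "the series" means these compounds.

Measured compounds:
- compound 1, `COc1ccc(/C=C(/SCc2ccc(F)cc2)C(=O)c2ccc(Br)cc2)cc1O`: 1000 nM
- compound 2, `O=C(/C(=C\c1c[nH]c2ccc(Cl)cc12)SCc1ccc(F)cc1)c1ccc(Br)cc1`: 1000 nM
- compound 3, `COc1ccc(/C=C(/SCc2ccc(F)cc2)C(=O)c2ccc(Br)cc2)cc1`: 50000 nM

In a functional assay on DU-145 cells (Homo sapiens) for inhibition, read by trypan blue exclusion, with a stated time of 96 h (on this read-out lower numbers stand for stronger inhibition of growth and higher numbers for weaker inhibition of growth), compound 3 gives 50000 nM and stands with the highest number of the three. The nearest measured compound is compound 1, reached by a 50-fold higher number from compound 1 to compound 3 (1.70 log units; beyond the scatter), which is the change from hydroxy to hydrogen on an aromatic carbon. The step of a 50-fold higher number from compound 2 to compound 3 (1.70 log units; beyond the scatter) is of the same size. Between compound 1 and compound 2 the step of no change at the digits printed from compound 1 to compound 2 (within the scatter).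

Compound 4, `Cc1cc(C)cc(/C=C(/SCc2ccc(F)cc2)C(=O)c2ccc(Br)cc2)c1`, differs from compound 3 by 3,5-dimethylphenyl in place of 4-methoxyphenyl on a double-bonded chain carbon bound to a double-bonded chain carbon. For the measured compounds named here, no measured step covers this exact exchange; the two large steps that end at compound 3 both alter the same aryl position, so the region is clearly sensitive, but the direction for a ring with no hydrogen-bond acceptor is unknown. The expected step of a 1.3-fold lower number from compound 3 to compound 4 (0.10 log units; within the scatter) is therefore estimated as small, with wide uncertainty. Compound 4 is expected to give about 40000 nM in this assay, estimated between 6000 nM and 250000 nM.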

Compound 4, concentration for 50% growth inhibition: 10000 nM
Compound 4: middle estimate off by 4.0-fold (0.60 log units), on the high side, and the stated range covers the measured number.
By their numbers in this assay, from the lowest: compounds 1 and 2 (each within the scatter of the next); then compound 4; then compound 3.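

In this assay the step of a 5.0-fold lower number from compound 3 to compound 4 (0.70 log units; beyond the scatter) shows that this position responds beyond the scatter to 3,5-dimethylphenyl, a ring counted with 0 hydrogen-bond donors and 0 hydrogen-bond acceptors, so a hydrogen-bond acceptor on this ring is not needed for the lower number. Even so, 3,5-dimethylphenyl does not match the other two groups at this position: the step of a 10-fold higher number from compound 1 to compound 4 (1.00 log units; beyond the scatter) from 3-hydroxy-4-methoxyphenyl and the step of a 10-fold higher number from compound 2 to compound 4 (1.00 log units; beyond the scatter) from 5-chloro-1H-indol-3-yl both end at a higher number. No measurement at hand accounts for these differences.

As far as these compounds go, it remains open whether an amine or a carboxylic acid on this ring would lower the number of compound 4 or raise it. Also open, from the compounds shown here alone, is whether a single methyl group would give the same result as the two in 3,5-dimethylphenyl.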